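Cytotoxicity of Sulfonyl Piperidine Analogues

The compounds below may be only part of what the source reports. "The series", "measured", "known", "first", "only" and "open" are said of these compounds alone.

Compound 1 `CC1CCN(C2CCN(S(=O)(=O)c3cn(C)cn3)CC2)CC1` gives in an ADME assay on HCT-116 cells (Homo sapiens) for cytotoxicity, read by CellTiter-Glo, with a stated time of 72 h (a lower number here means a stronger inhibitor, a higher number a weaker inhibitor), only the limit > 10000 nM.
Compound 2 `COc1ccccc1-c1ccc(S(=O)(=O)N2CCC(N3CCC(C)CC3)CC2)cc1` gives in this assay only the limit > 5000 nM.
Compound 3 `CC1CCN(C2CCN(S(=O)(=O)c3ccccc3-c3ccc(C(F)(F)F)cc3)CC2)CC1` gives in this assay only the limit > 5000 nM.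

Compound 2 therefore stands at the limit of > 5000 nM in this assay, at which 2 of the 3 values shown sit, so no number is known for it, and the other two values are limits as well. Compound 4 `CC1CCN(C2CCN(S(=O)(=O)c3ccc(C#N)cc3)CC2)CC1` differs from compound 2 by cyano in place of 2-methoxyphenyl on an aromatic carbon. Since no measured step connects any two of these compounds, there is no basis for predicting a change in this assay beyond the scatter, and compound 4 is expected to remain at a limit, with a step that the limit leaves unreadable from compound 2 to compound 4 as the estimated step. Compound 4 is estimated at 10000 nM, with a range from 3000 nM to 40000 nM.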

Compound 4, half-maximal inhibitory concentration: > 5000 nM
Compound 4: no number, only a limit (the forecaster's own chance of this, stated with the estimate: 80%); the middle value lies beyond the limit too.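

Compound 1, compound 2 and compound 4 all give only limits in this assay, so neither the step from compound 2 to compound 4 nor that from compound 1 to compound 4 can be read. The compounds shown leave open what actual half-maximal inhibitory concentration any of them has in this assay.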